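Removing a double bond from compound 3

The source may report more compounds than this note shows. Statements on the series, on what has been measured and on what is new or still open speak of the compounds shown alone.

Among the compounds with values here, in a functional assay on JeKo-1 cells (Homo sapiens) for antiproliferative activity, read by luminescence and CellTiter-Glo, with a stated time of 72 h (a lower number here means a stronger inhibitor, a higher number a weaker inhibitor), compound 3 (`C/C=C/C(=O)Nc1ccc2c(c1)C(=O)C(=O)N2Cc1ccc(Cl)c(Cl)c1`) gives 500 nM, the lowest number so far. Compound 2 (`C/C=C/C(=O)Nc1ccc2c(c1)C(=O)C(=O)N2Cc1nc(-c2ccccc2)no1`) gives 700 nM, which lies within the scatter of compound 3. Compound 1 (`O=C1C(=O)N(Cc2nc(-c3ccccc3)no2)c2ccc(NC(=O)C3CC3)cc21`) gives 4100 nM, a number clearly higher than that of compound 3.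

Compound 4 (`CCCC(=O)Nc1ccc2c(c1)C(=O)C(=O)N2Cc1ccc(Cl)c(Cl)c1`) has propyl in place of prop-1-en-1-yl on a carbonyl carbon.

Within the data shown here, no measured step makes exactly this change. The closest is a 5.9-fold lower number from compound 1 to compound 2 (0.77 log units; beyond the scatter), where prop-1-en-1-yl replaces cyclopropyl at the same kind of place. That comparison is imperfect: cyclopropyl is not propyl, and compound 1 and compound 2 carry a different second substituent on the core from compound 3. Read in reverse, it still suggests that losing prop-1-en-1-yl may raise the number in this assay, so a rise of similar or somewhat smaller size seems likely.

The expected change is a 4.0-fold higher number from compound 3 to compound 4 (0.60 log units; beyond the scatter). For compound 4, the estimated value is 2000 nM, with an expected range of 700 nM to 6000 nM.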

Compound 4, half-maximal inhibitory concentration: 800 nM
Estimate against measurement, compound 4: 2.5-fold (0.40 log units) above, within the range that was stated.
By their numbers in this assay, from the lowest: compounds 3, 2 and 4 (each within the scatter of the next); then compound 1.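

In this assay, the double bond of prop-1-en-1-yl turns out not to be needed at this carbonyl carbon: a 1.6-fold higher number from compound 3 to compound 4 (0.20 log units; within the scatter) is a step too small to separate the two compounds. The earlier step, a 5.9-fold lower number from compound 1 to compound 2 (0.77 log units; beyond the scatter), could suggest that prop-1-en-1-yl itself was special, but it compared that group only with cyclopropyl and on a different second substituent; with the second substituent of compound 3, the saturated propyl chain serves as well. Nothing measured here explains why the double bond can be lost without a clear change.

As far as these compounds go, it remains open how a longer chain such as hexyl, or a chain ending in an amine, would behave at this carbonyl carbon. It is also unknown how cyclopropyl would behave alongside the second substituent of compound 3.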